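Methylation of the phenol in the cyclohexanone series

The compounds below may be only part of what the source reports. "The series", "measured", "known", "first", "only" and "open" are said of these compounds alone.

Compound 1 `O=C1/C(=C/c2ccccc2)CCC/C1=C\c1ccc(Cl)cc1`: 27.6%
Compound 2 `O=C1/C(=C/c2ccccc2)CCC/C1=C\c1ccc(O)cc1`: 53%
Compound 3 `O=C(/C=C(O)/C=C/c1ccc(O)cc1O)c1ccccc1O`: 61.2%

In an assay on isolated protein for inhibition of Alpha glucosidase (Homo sapiens), with stated times of 5 min and 15 min, tested at 50 uM (on this read-out higher numbers stand for more inhibition at the one concentration tested (going by the name of the read-out) and lower numbers for less inhibition), compound 2 gives 53%, the second highest of the three numbers; its gap to compound 3 lies within the scatter, while compound 1 sits well below it. The step from compound 2 to compound 4 `COc1ccc(/C=C2\CCC/C(=C\c3ccccc3)C2=O)cc1` reads (methyl in place of hydrogen on an oxygen on an aromatic ring). Among the measured compounds shown here, no measured step covers this change directly. The nearest is a number 25.4 percentage points higher from compound 1 to compound 2 (beyond the scatter), which shows that what the oxygen on the aromatic ring carries matters in this assay, though it does not say how the methyl will behave. A drop from compound 2 is expected, of moderate size, a number 18 percentage points lower from compound 2 to compound 4 (beyond the scatter), with wide uncertainty. Compound 4 is therefore estimated at 35%, within a range of 20% to 50%.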

Compound 4, a percentage reported as inhibition, at one concentration (the size of the read-out at that concentration, not a potency): 31.4%
Compound 4: the middle estimate sits 3.6 percentage points above what was measured; measured number inside the range.
By their numbers in this assay, from the lowest: compounds 1 and 4 (each within the scatter of the next); then compounds 2 and 3 (each within the scatter of the next).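

In this assay, methyl on the oxygen on the aromatic ring gives a number 21.6 percentage points lower from compound 2 to compound 4 (beyond the scatter), so an oxygen at this place does not by itself carry the higher number. Methoxy and chloro are not separated here, with a number 3.8 percentage points higher from compound 1 to compound 4 (within the scatter). No measurement shown bears on the reason for either step. Open, from the compounds shown here alone, is whether an amine or a carboxylic acid on the same aromatic carbon would read with compound 2 or with compound 1 and compound 4. Also open, going by these compounds, is how a longer chain on the oxygen, such as ethyl, would read.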